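A few compounds are considered here, and "the series" means these few. Any claim that something is new, unique, unknown or untested is made for them only; others in the source may bear on it.

In a functional assay on A549 cells (Homo sapiens) for cytotoxicity, read by resazurin assay, with a stated time of 72 h (a higher number here means a weaker inhibitor, a lower number a stronger inhibitor), compound 1 `N#Cc1cc(-c2ccccc2)n(-c2ccc(Cl)cc2)c1N` gives 7700 nM, compound 2 `N#Cc1cc(-c2ccccc2)n(-c2nc3ccccc3[nH]2)c1N` gives 12100 nM, and compound 3 `N#Cc1cc(-c2ccccc2)n(Cc2nc3ccccc3[nH]2)c1N` gives 12000 nM. These numbers lie within the usual scatter of one another, so compound 3 cannot be separated from the other two. Compound 4 `Nc1c(-c2nc3ccccc3[nH]2)cc(-c2ccccc2)n1Cc1nc2ccccc2[nH]1` differs from compound 3 by one change, 1H-benzimidazol-2-yl in place of cyano on an aromatic carbon. For the measured compounds named here, no measured pair shows a change at this place, so the size of the step in this assay is uncertain. A modest move towards a lower number is expected, possibly no larger than the scatter. The estimated change is a 1.8-fold lower number from compound 3 to compound 4 (0.27 log units; within the scatter). For compound 4, the estimated value is 6500 nM, with an expected range of 2000 nM to 20000 nM.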

Compound 4, half-maximal inhibitory concentration: 5100 nM
Compound 4: the middle estimate sits 1.3-fold (0.11 log units) above what was measured; low and high end bracket the measured number.
By their numbers in this assay, from the lowest: compounds 4, 1, 3 and 2 (each within the scatter of the next, the first and the last beyond it).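

In this assay, for the compounds shown here, replacing cyano with 1H-benzimidazol-2-yl on this aromatic carbon gives a 2.4-fold lower number from compound 3 to compound 4 (0.37 log units; beyond the scatter) and is the first step read at this position. It shows that a far larger group, with two aromatic rings, can sit here without the number rising. No measurement shown explains the step. Still open, going by these compounds, is whether a small group at this carbon, such as an amine or a carboxylic acid, would move the number, and whether the same swap gives a similar step in a compound with a different group on the ring nitrogen.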